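Replacing the free amine with a benzyl methylsulfonamide

The compounds below may be only part of what the source reports. "The series", "measured", "known", "first", "only" and "open" are said of these compounds alone.

Measured compounds:
compound 1, `CCCCc1ccc(CN(C(C)C)S(C)(=O)=O)c(=O)n1Cc1ccc(-c2ccccc2-c2nn[nH]n2)cc1`, 82.7%
compound 2, `CCCCc1ccc(CN(Cc2ccccc2)S(=O)(=O)c2ccccc2)c(=O)n1Cc1ccc(-c2ccccc2-c2nn[nH]n2)cc1`, 75.7%
compound 3, `CCCCc1ccc(CN)c(=O)n1Cc1ccc(-c2ccccc2-c2nn[nH]n2)cc1`, 2.8%

In a functional assay on the whole organism (artery) for inhibition, with Rattus norvegicus as the target, at a dose of 3 mg/kg by the intraduodenal route (on this read-out higher numbers stand for more inhibition at the one dose given (going by the name of the read-out) and lower numbers for less inhibition), compound 3 stands lowest of the three numbers. Its nearest neighbour is compound 2, and its furthest is compound 1; both gaps are beyond the scatter. The step of a number 79.9 percentage points lower from compound 1 to compound 3 (beyond the scatter) shows how much is lost when the sulfonamide nitrogen is stripped back to a free amine.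

Compound 4, `CCCCc1ccc(CN(Cc2ccccc2)S(C)(=O)=O)c(=O)n1Cc1ccc(-c2ccccc2-c2nn[nH]n2)cc1`, has not yet been measured in this assay. It differs from compound 3 in one place: benzyl(methylsulfonyl)amino in place of amino on a saturated chain carbon bound to an aromatic carbon. Among the measured compounds shown here, the only measured step that bears on this change is the one from compound 1 to compound 3, which was large; compound 4 reverses that direction, and it carries a benzyl group on the nitrogen as compound 2 does and a methylsulfonyl group as compound 1 does. Both of those compounds give high inhibition in this assay.

Compound 4 is therefore expected to return to the level of compounds 1 and 2, with an estimate of 78% in this assay and a range from 60% to 90%. The expected step is a number 75.2 percentage points higher from compound 3 to compound 4 (beyond the scatter), a rise well beyond the scatter.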

Compound 4, a percentage reported as inhibition, in the whole organism at one dose (the size of the read-out at that dose, not a potency): 41.2%
For compound 4 the middle estimate is 36.8 percentage points above the measured one; measured number outside the range, below it.
By their numbers in this assay, from the lowest: compound 3; then compound 4; then compounds 2 and 1 (each within the scatter of the next).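

In this assay, putting benzyl(methylsulfonyl)amino in place of amino on the saturated chain carbon recovers only part of the inhibition, a number 38.4 percentage points higher from compound 3 to compound 4 (beyond the scatter), so a sulfonamide at this position does not by itself secure a high number. The groups on it separately matter, which compounds 1 and 2 could not show, as they differ from each other at both the nitrogen and the sulfur: with benzyl kept on the sulfonamide nitrogen, methyl in place of phenyl on the sulfonyl sulfur gives a number 34.5 percentage points lower from compound 2 to compound 4 (beyond the scatter), and with methyl kept on the sulfonyl sulfur, benzyl in place of isopropyl on the nitrogen gives a number 41.5 percentage points lower from compound 1 to compound 4 (beyond the scatter). No measurement at hand bears on the reason for these steps.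

The compounds shown leave open whether isopropyl on the nitrogen would hold its number with phenyl on the sulfonyl sulfur, and whether an ethyl group or a longer chain on that sulfur would fall nearer compound 4 or compound 2. They also leave open how an acetyl group, a carbonyl in place of the sulfonyl, would read on the same nitrogen.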